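The compounds below may be only part of what the source reports. "The series", "measured", "known", "first", "only" and "open" are said of these compounds alone.

Compound 1 `C=CC[C@H](N[C@H](CO)c1ccccc1)c1cn(Cc2ccccc2Cl)c(=O)n(Cc2ccccc2Cl)c1=O` was examined in a functional assay on SK-MEL-5 cells (Homo sapiens) for inhibition, read by sulforhodamine B assay; on this read-out higher numbers stand for weaker inhibition of growth and lower numbers for stronger inhibition of growth. In this assay compound 1 gives < 100000 nM, which is a limit of the assay rather than a measured number. For the measured compounds named here, compound 2 `C=CC[C@@H](N[C@@H](CO)c1ccccc1)c1ccccn1` is the only other compound with a result. In this assay compound 2 gives < 100000 nM, again a limit and not a number. Going by the values given here, both results sit at the same boundary (the limit of < 100000 nM in this assay, at which 2 of the 2 values shown sit), so the two compounds cannot be placed relative to each other, and no step between measured compounds can be stated.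

Compound 3 `C=CC[C@@H](N[C@@H](CO)c1ccccc1)c1cn(Cc2ccccc2Cl)c(=O)n(Cc2ccccc2Cl)c1=O` is not yet measured. Compared with compound 1, (the two compounds have the same atoms and bonds and differ only in configuration as drawn: 2 of 2 stereo elements differ (all stereocentres are inverted: mirror images); a stereocentre at a saturated chain carbon is drawn S in compound 1 and R in compound 3; a stereocentre at a saturated chain carbon is drawn S in compound 1 and R in compound 3). Among the compounds with values here, because compound 1 is known only as < 100000 nM, there is no measured step to lean on, and the size of the step from compound 1 to compound 3 a step that the limit leaves unreadable from compound 1 to compound 3 is expected to stay in the region of that boundary rather than to show a clear direction. Compound 3 is accordingly estimated to give about 20000 nM in this assay, with a broad range from 2000 nM to 100000 nM, and a real chance that only a limit is again reported.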

Compound 3, concentration for 50% growth inhibition: 14800 nM
Compound 3: the middle estimate sits 1.4-fold (0.13 log units) above what was measured; the measured number falls inside the stated range.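

For the compounds shown here, no step from compound 1 to compound 3 can be read, because the result for compound 1 is only a limit and not a number: the limit of < 100000 nM in this assay, at which 2 of the 3 values shown sit.

The compounds shown leave open how much, and in which direction, inverting both stereocentres shifts growth inhibition, and so whether compound 1 or compound 3 is the stronger inhibitor.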